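This account rests on a few compounds, and the source may have more. Where it says the series, first, only, none or still open, it means among the compounds named here.

Measured in a functional assay on HepG2 cells (Homo sapiens) for antiproliferative activity, read by sulforhodamine B assay, with a stated time of 72 h; a higher number here means a weaker inhibitor, a lower number a stronger inhibitor:
- compound 1 `COc1ccc(NC(=O)Cn2nc(-c3ccccc3)c3ccccc3c2=O)cc1`: > 100000000 nM (a limit of the assay)
- compound 2 `O=C(Cn1nc(-c2ccccc2)c2ccccc2c1=O)Nc1cccc(C(F)(F)F)c1`: 3500 nM
- compound 3 `COc1ccc(NC(=O)Cn2nc(Cc3ccccc3)c3ccccc3c2=O)cc1`: 69000 nM

Compound 3 stands at 69000 nM, the higher of the two actual numbers, while compound 2 lies lower at 3500 nM. The entry for compound 1 is a limit, not a number.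

Compound 4 `O=C(Cn1nc(Cc2ccccc2)c2ccccc2c1=O)Nc1ccc(Cl)cc1` keeps the benzyl group of compound 3 and has chloro in place of methoxy on an aromatic carbon, para to a large group: chloro in place of methoxy on an aromatic carbon. Read one bond further out, this is 4-methoxyphenyl to 4-chlorophenyl.

Within the data shown here, the closest precedent is an at least 28000-fold lower number from compound 1 to compound 2 (4.45 log units; beyond the scatter), which also removes the 4-methoxyphenyl, though a different group enters. Its size is only a bound, since it starts from a limit. The other step, an at least 1400-fold lower number from compound 1 to compound 3 (3.16 log units; beyond the scatter), changes a different place and has the same kind of bound. Among the measured compounds shown here, no measured compound shows how the two changes combine. A step to a lower number is therefore expected in this assay, modest but beyond the scatter and much smaller than an at least 28000-fold lower number from compound 1 to compound 2 (4.45 log units; beyond the scatter). The expected change is a 4.6-fold lower number from compound 3 to compound 4 (0.66 log units; beyond the scatter). Compound 4 is expected at 15000 nM, with an estimated range from 3000 nM to 80000 nM.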

Compound 4, half-maximal inhibitory concentration: > 100000000 nM
Compound 4 gave a limit, no number; the forecaster's own chance of this, stated with the estimate: 10%; at least 6600-fold (3.82 log units) between middle value and limit.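

With the benzyl group in place, chloro in place of methoxy on an aromatic carbon, para to a large group, gives an at least 1400-fold higher number from compound 3 to compound 4 (3.16 log units; beyond the scatter) in this assay. The earlier step of an at least 28000-fold lower number from compound 1 to compound 2 (4.45 log units; beyond the scatter) therefore does not extend to every loss of the 4-methoxyphenyl: in the benzyl compounds shown, the 4-methoxyphenyl belongs to the compound with a measured number, and the 4-chlorophenyl does not. Compound 4 gives > 100000000 nM, a limit of the assay and not a number, and the step is only a bound whose true size stays unknown: the limit of > 100000000 nM in this assay, at which 2 of the 4 values shown sit.

Still open, going by these compounds, is whether the 3-(trifluoromethyl)phenyl of compound 2 keeps a measurable number alongside the benzyl group of compound 3, and whether the 4-chlorophenyl would behave the same way with the phenyl group of compound 1. Also open, on these data alone, is how other groups at this aromatic carbon, such as fluoro, an amine or a carboxylic acid, would read in this assay, which leaves undecided whether the loss is specific to chloro or extends to any replacement of methoxy here.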